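A few compounds are considered here, and "the series" means these few. Any claim that something is new, unique, unknown or untested is made for them only; others in the source may bear on it.

Three compounds share one core and were taken into a functional assay on MCF7 cells (Homo sapiens) for cytotoxicity, read by MTT assay, with a stated time of 48 h; on this read-out lower numbers stand for stronger inhibition and higher numbers for weaker inhibition. For compound 1 `Cn1c(/C=C2/C(=O)Nc3ccc([N+](=O)[O-])cc32)nc2ccccc21` no figure exists; in this assay compound 1 is recorded as "not determined" (no result reported). Compound 2 `Cn1c(/C=C2/C(=O)Nc3ccc(Br)cc32)nc2ccccc21` carries bromo on an aromatic carbon. In this assay compound 2 gives > 50000 nM, which is a limit of the assay and not a number. Compound 3 `Cn1c(/C=C2/C(=O)Nc3ccc(F)cc32)nc2ccccc21` carries fluoro in place of bromo on that aromatic carbon, and in this assay compound 3 gives 31600 nM. Within the data shown here, the single measured step is an at least 1.5-fold lower number from compound 2 to compound 3 (0.19 log units; that floor lies within the scatter), and its floor lies within the scatter, so the two compounds cannot be ordered with confidence. Compound 2 thus stands at the limit of > 50000 nM in this assay, at which 1 of the 3 values shown sits, with no number of its own.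

Compound 4 `CC(C)n1c(/C=C2/C(=O)Nc3ccc(Br)cc32)nc2ccccc21` differs from compound 2 by isopropyl in place of methyl on an aromatic nitrogen. Among the measured compounds shown here, no measured step concerns the aromatic nitrogen; the only step available exchanges fluoro for bromo on an aromatic carbon and therefore does not speak to this change. With nothing to point toward a gain or a loss, the writer expects no step beyond the scatter, so that a step that the limit leaves unreadable from compound 2 to compound 4 is the expected outcome. Compound 4 is estimated at 60000 nM, within a range from 20000 nM to 200000 nM.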

Compound 4, half-maximal inhibitory concentration: 14900 nM
Estimate against measurement, compound 4: 4.0-fold (0.60 log units) above, and the stated range ends above it.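

Among these compounds, the aromatic nitrogen had not been varied among the earlier compounds, and it now proves to be a place where the read-out moves: in this assay, isopropyl in place of methyl gives an at least 3.3-fold lower number from compound 2 to compound 4 (0.52 log units; beyond the scatter). Unlike the exchange of bromo for fluoro, whose floor lies within the scatter, this step lies beyond it, so it is the first in the series that orders two compounds with confidence, and compound 4 stands on the side of stronger inhibition. The full size of the step stays unknown because compound 2 has only a limit and no number of its own: the limit of > 50000 nM in this assay, at which 1 of the 4 values shown sits.

The compounds shown leave open whether an ethyl group, a cyclopropyl ring or a longer chain on that aromatic nitrogen would lower the number further or raise it again, and so whether the size or the branching of the isopropyl group matters. They also leave open whether the same exchange would carry over with fluoro or nitro in place of bromo on the aromatic carbon, since this single pair establishes no pattern.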